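Trifluoromethyl Moved on the Benzyl Ester: Compound 4

The source may report more compounds than this note shows. Statements on the series, on what has been measured and on what is new or still open speak of the compounds shown alone.

Measured compounds:
compound 1, `O=C(OCc1ccccc1Br)c1cccc(=O)[nH]1`, gives 59000 nM
compound 2, `O=C(OCc1ccccc1)c1cccc(=O)[nH]1`, gives 69000 nM
compound 3, `O=C(OCc1cccc(C(F)(F)F)c1)c1cccc(=O)[nH]1`, gives only a limit, > 150 nM

All three were tested in an assay on isolated protein for inhibition of matrix metalloproteinase-9 (Homo sapiens); a higher number here means a weaker inhibitor, a lower number a stronger inhibitor. Compound 2 holds the highest of the two numbers reported there; its nearest neighbour is compound 1, and the step of a 1.2-fold higher number from compound 1 to compound 2 (0.07 log units; within the scatter) lies within the scatter. For compound 3 the assay reported a limit rather than a number, (the limit of > 150 nM in this assay, at which 1 of the 3 values shown sits). The step that the limit leaves unreadable from compound 2 to compound 3 therefore cannot be read. Compound 4, `O=C(OCc1ccc(C(F)(F)F)cc1)c1cccc(=O)[nH]1`, differs from compound 2 by trifluoromethyl in place of hydrogen on an aromatic carbon. Going by the values given here, the only measured step that brings a trifluoromethyl onto this ring is the unreadable one, and the step from compound 1 to compound 2 concerns a different group. The expectation for compound 4 thus rests on compound 2 alone, whose value in this assay is 69000 nM. Compound 4 is estimated at 60000 nM, within 15000 nM to 200000 nM. The expected step of a 1.2-fold lower number from compound 2 to compound 4 (0.06 log units; within the scatter) is none beyond the scatter, with wide uncertainty.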

Compound 4, half-maximal inhibitory concentration: 101000 nM
The estimate for compound 4 lay 1.7-fold (0.23 log units) below the measured number, and the stated range covers the measured number.
By their numbers in this assay, from the lowest: compounds 1, 2 and 4 (each within the scatter of the next).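

In this assay, going by these compounds alone, putting trifluoromethyl on an aromatic carbon, para to a large group, gives the first readable step for this change: a 1.5-fold higher number from compound 2 to compound 4 (0.17 log units; within the scatter). A group of 4 heavy atoms in place of a hydrogen at this position therefore produces no difference beyond the scatter, and compound 2 and compound 4 stand level within it. No measurement shown here offers a cause for this result.

From the compounds shown here alone, compound 3 gives only a limit, not a number, so the step to it cannot be read, and the effect of trifluoromethyl at that other place on the ring stays open: the limit of > 150 nM in this assay, at which 1 of the 4 values shown sits. Also open, going by these compounds, is whether an amine or a carboxylic acid at the position used in compound 4 would give a number beyond the scatter of compound 2.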